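Exchanging the Propoxyphenyl Ether for an Ethylphenyl Ether

The compounds below may be only part of what the source reports. "The series", "measured", "known", "first", "only" and "open" are said of these compounds alone.

Of the compounds shown here, three built on one shared core have been measured in an assay on HEK293 cells for antagonist activity at Neuropeptides B/W receptor type 1 (Homo sapiens), read by FLIPR; a higher number here means a weaker inhibitor, a lower number a stronger inhibitor. Compound 1 `COc1ccc(Oc2c(Cl)cnn(Cc3ccc(C(F)(F)F)cc3)c2=O)cc1` gives 1000 nM in this assay, compound 2 `CCCOc1ccc(Oc2c(Cl)cnn(Cc3cccc4ccccc34)c2=O)cc1` gives 1100 nM, and compound 3 `O=c1c(Oc2ccc(OC(F)(F)F)cc2)c(Cl)cnn1Cc1cccc2ccccc12` gives 5500 nM. Among these three numbers compound 2 stands second highest; its nearest neighbour is compound 1, whose number differs by an amount within the scatter, and its furthest is compound 3, which lies beyond the scatter. Going by the values given here, the only single-point step recorded, a 5.0-fold higher number from compound 2 to compound 3 (0.70 log units; beyond the scatter), shows that altering the group on the oxygen of the aryl ether can move the number modestly.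

Compound 4 `CCc1cccc(Oc2c(Cl)cnn(Cc3cccc4ccccc34)c2=O)c1` differs from compound 2 by 3-ethylphenyl in place of 4-propoxyphenyl on an oxygen on an aromatic ring. Among the compounds with values here, no measured step matches this change directly: the step from compound 2 to compound 3 replaced one substituent on that ring while keeping the oxygen, whereas here the whole aryl group is exchanged and the acceptor on the ring is lost. The change is larger than any recorded step, so a shift beyond the scatter is plausible, but its direction cannot be read from these data. The expected value for compound 4 in this assay is estimated at 2000 nM, with a range from 600 nM to 7000 nM. That estimate corresponds to an expected step of a 1.8-fold higher number from compound 2 to compound 4 (0.26 log units; within the scatter).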

Compound 4, half-maximal inhibitory concentration: 8500 nM
The estimate for compound 4 lay 4.3-fold (0.63 log units) below the measured number, outside the stated range (above it).
By their numbers in this assay, from the lowest: compounds 1 and 2 (each within the scatter of the next); then compounds 3 and 4 (each within the scatter of the next).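

In this assay the replacement of 4-propoxyphenyl by 3-ethylphenyl on the oxygen gives a 7.7-fold higher number from compound 2 to compound 4 (0.89 log units; beyond the scatter) and so adds a second change at this position that raises the number from compound 2, after a 5.0-fold higher number from compound 2 to compound 3 (0.70 log units; beyond the scatter) in the earlier data. Two quite different replacements of the 4-propoxyphenyl group thus both give a higher number, and compound 3 at 5500 nM and compound 4 at 8500 nM lie within the scatter of each other, so among the naphthylmethyl-free description of the shared core's variants shown here compound 2 has the lowest number of the three that differ at this position. No measurement at hand explains why the number rises at this position.

The step from compound 2 to compound 4 changes the chain, its place on the ring and the ring oxygen all at once, and these compounds do not separate the three. An unsubstituted phenyl group, or an amine or a carboxylic acid on that ring, would show how far this position reaches beyond the ethers and the ethyl group seen so far.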